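Methyl versus benzyl on selenium in two bis-acyl isoselenoureas

This account rests on a few compounds, and the source may have more. Where it says the series, first, only, none or still open, it means among the compounds named here.

Compound 3 `O=C(/N=C(/NC(=O)c1cccs1)[Se]Cc1ccccc1)c1cccs1` and compound 2 `O=C(/N=C(/NC(=O)c1ccno1)[Se]Cc1ccccc1)c1ccno1` both carry the benzyl on selenium; the difference between their two cores is not broken down here. In a functional assay on K562 cells (Homo sapiens) for cytotoxicity, read by MTT assay, with a stated time of 72 h (a higher number here means that more compound is tolerated, a lower number that less compound is tolerated), compound 3 gives 87400 nM and compound 2 gives 94700 nM, two numbers within the usual scatter of each other. Compound 1 `C[Se]/C(=N\C(=O)c1cccs1)NC(=O)c1cccs1` carries the change (hydrogen in place of phenyl on a saturated chain carbon bound to a selenium atom). In this assay compound 1 reaches only a limit, > 100000 nM, so the step of an at least 1.1-fold higher number from compound 3 to compound 1 (0.05 log units; that floor lies within the scatter) is read against (the limit of > 100000 nM in this assay, at which 1 of the 3 values shown sits). Compound 4 `C[Se]/C(=N\C(=O)c1ccno1)NC(=O)c1ccno1` carries the same change on the core of compound 2, (hydrogen in place of phenyl on a saturated chain carbon bound to a selenium atom), and is not yet measured. Because compound 2 gives 94700 nM and because the matching step an at least 1.1-fold higher number from compound 3 to compound 1 (0.05 log units; that floor lies within the scatter) points upward, a step of a 1.2-fold higher number from compound 2 to compound 4 (0.07 log units; within the scatter) is expected. Compound 4 is therefore estimated at 110000 nM, between 60000 nM and 250000 nM, with a real chance of again only a limit.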

Compound 4, concentration lethal to 50% of the cells: > 100000 nM
Compound 4 ended at the assay's limit (the forecaster's own chance of this, stated with the estimate: 60%); the middle value lies beyond the limit too.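

Replacing benzyl by methyl on selenium gives an at least 1.0-fold higher number from compound 2 to compound 4 (0.02 log units; that floor lies within the scatter) in this assay. Neither core shows a step beyond the scatter, and neither step has a measured size, so nothing shows that the change carries over from one core to the other by the same amount: the same change on two cores in this assay, an at least 1.1-fold higher number (0.05 log units; that floor lies within the scatter) from compound 3 to compound 1 and an at least 1.0-fold higher number (0.02 log units; that floor lies within the scatter) from compound 2 to compound 4; the limit leaves it open whether they differ. Compound 4 gives > 100000 nM, which is a limit of the assay and not a number, and such limits now make up part of the series: the limit of > 100000 nM in this assay, at which 2 of the 4 values shown sit.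

The compounds shown leave open how a longer chain on selenium, or a benzyl carrying an amine, would read on either core. From the compounds shown here alone, whether any such group gives a value clear of the limit also stays open.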